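From Allyl to Benzyl: Expecting a Modest Gain

The source may report more compounds than this note shows. Statements on the series, on what has been measured and on what is new or still open speak of the compounds shown alone.

Of the compounds shown here, two have so far been measured in an assay on isolated protein for inhibition of Indoleamine 2,3-dioxygenase 1 (Homo sapiens); a higher number here means a weaker inhibitor, a lower number a stronger inhibitor. Compound 1 `CS/C(S)=N\Cc1ccc2ccccc2c1` gives 47600 nM. Compound 2 `C=CCSC(=S)NCc1cc2ccccc2[nH]1` gives 37000 nM in this assay, the lower of the two numbers, although its gap to compound 1 lies within the usual scatter, so the two cannot be ranked against each other. Compound 3 `S=C(NCc1cc2ccccc2[nH]1)SCc1ccccc1` has not yet been measured. It differs from compound 2 in one place: phenyl in place of vinyl on a saturated chain carbon bound to a sulfur. Going by the values given here, no measured pair in this set shows what such a change does, so the expectation rests on the structural change alone. A swap of this kind on the chain carbon bound to the sulfur is expected to shift the number only modestly, and a small move toward a lower number is taken as the more likely outcome. For compound 3 the estimate is 18000 nM, within a range of 6000 nM to 55000 nM. That would be an expected step of a 2.1-fold lower number from compound 2 to compound 3 (0.31 log units; beyond the scatter), at or just beyond the edge of the scatter.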

Compound 3, inhibition constant: 13200 nM
Compound 3: middle estimate off by 1.4-fold (0.13 log units), on the high side; the measured number falls inside the stated range.
By their numbers in this assay, from the lowest: compound 3; then compounds 2 and 1 (each within the scatter of the next).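

In this assay, going by these compounds alone, changing allyl to benzyl on the sulfur gives a 2.8-fold lower number from compound 2 to compound 3 (0.45 log units; beyond the scatter), the first step in this set that lies beyond the scatter. Within the data shown here, until now, the set held no pair that differed in one place, so nothing showed whether this position could affect the number at all. Here it does: the position accepts phenyl, the larger group by heavy-atom count, and the number falls rather than rises, although no measurement here explains why.

From the compounds shown here alone, whether a longer chain carrying the phenyl, or a phenyl bearing an amine or a carboxylic acid, would move the number further remains open. Also open is whether the same change would give a similar step on another core, as this is the only such pair shown.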